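Ortho substituent exchange on the phenyl ring: chloro to isobutyl

The source may hold more compounds than are shown below. What is called first, only, known or untested is meant among the compounds shown, and "the series" means these compounds.

Measured in an assay on cells with Cystic fibrosis transmembrane conductance regulator variant F508del (Homo sapiens) as the target, read by voltage clamp, with a stated time of 24 h, in the presence of a further agent that is not named here (on this read-out lower numbers stand for an effect already at smaller amounts and higher numbers for an effect only at larger amounts of compound), so far:
- compound 1 `COc1ncc(C(F)(F)F)cc1CO[C@H]1[C@H](C(C)(C)C)[C@@H](C(=O)O)N(C(=O)[C@@H]2CCCCO2)[C@H]1c1ccccc1`: 213 nM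
- compound 2 `COc1ncc(C(F)(F)F)cc1CO[C@H]1[C@H](C(C)(C)C)[C@@H](C(=O)O)N(C(=O)[C@@H]2CCCCO2)[C@H]1c1ccccc1C1CC1`: 66 nM
- compound 3 `COc1ncc(C(F)(F)F)cc1CO[C@H]1[C@H](C(C)(C)C)[C@@H](C(=O)O)N(C(=O)[C@@H]2CCCCO2)[C@H]1c1ccccc1Cl`: 222 nM

Compound 3 gives the highest number of the three, yet its value and that of compound 1 are within the scatter of each other (a 1.0-fold higher number from compound 1 to compound 3 (0.02 log units; within the scatter)), so the chloro group brought no real change against hydrogen. Compound 2 stands apart: a 3.2-fold lower number from compound 1 to compound 2 (0.51 log units; beyond the scatter) and a 3.4-fold higher number from compound 2 to compound 3 (0.53 log units; beyond the scatter) both lie beyond the scatter.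

Compound 4 `COc1ncc(C(F)(F)F)cc1CO[C@H]1[C@H](C(C)(C)C)[C@@H](C(=O)O)N(C(=O)[C@@H]2CCCCO2)[C@H]1c1ccccc1CC(C)C` is the next step from compound 3: isobutyl in place of chloro on an aromatic carbon. For the measured compounds named here, no measured pair exchanges chloro for isobutyl, so the nearest guide is the step from compound 2 to compound 3, where a carbon substituent in place of chloro went with a modestly lower number. Isobutyl is likewise a carbon substituent, though with no ring; a lower number than compound 3 is therefore expected, of modest size, and the step of a 2.5-fold lower number from compound 3 to compound 4 (0.39 log units; beyond the scatter) is estimated on that basis. For compound 4 the expected value in this assay is 90 nM, with a range from 35 nM to 250 nM.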

Compound 4, half-maximal effective concentration: 52 nM
The estimate for compound 4 lay 1.7-fold (0.24 log units) above the measured number; low and high end bracket the measured number.
By their numbers in this assay, from the lowest: compounds 4 and 2 (each within the scatter of the next); then compounds 1 and 3 (each within the scatter of the next).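

In this assay an open-chain carbon substituent serves this position as well as the cyclopropyl ring: a 1.3-fold lower number from compound 2 to compound 4 (0.10 log units; within the scatter), so among these compounds the ring itself is not required for the low number. The isobutyl group also stands clear of both smaller substituents, with a 4.3-fold lower number from compound 3 to compound 4 (0.63 log units; beyond the scatter) and a 4.1-fold lower number from compound 1 to compound 4 (0.61 log units; beyond the scatter), which places compound 2 and compound 4 together, apart from compound 1 and compound 3, which carry hydrogen and chloro. No supporting data accompany these numbers to explain the split.

Open, going by these compounds, is whether a longer chain or a cyclohexyl group at this position lowers the number further or raises it again. Also open, on these data alone, is whether a methoxy group or an amine here would match the values of compound 2 and compound 4.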